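Swapping the ring on the thiocarbonyl of compound 1

The compounds below may be only part of what the source reports. "The series", "measured", "known", "first", "only" and "open" are said of these compounds alone.

Measured compounds and their growth inhibition values:
compound 1 `N/C(=N\NC(=S)N1CCCC1)c1ccc(F)cn1` gives 72.2%
compound 2 `Cc1cccc(/C(N)=N/NC(=S)N2CCSCC2)n1` gives 51.7%
compound 3 `N/C(=N\NC(=S)N1CCSCC1)c1ccccn1` gives 37.2%

These three compounds were tested in a functional assay on A-431 cells (Homo sapiens) for cytotoxicity, read by MTT assay, with a stated time of 72 h, tested at 3 uM; on this read-out lower numbers stand for less inhibition of growth and higher numbers for more inhibition of growth at the one concentration tested. Compound 1 stands highest of the three numbers, its nearest neighbour being compound 2 and the furthest compound 3, with both gaps reported as beyond the usual scatter.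

Among the measured compounds shown here, the only step measured between two compounds that differ in a single place runs a number 14.5 percentage points lower from compound 2 to compound 3 (beyond the scatter), which exchanges hydrogen for methyl on an aromatic carbon. That step does not touch the ring on the thiocarbonyl carbon and so says nothing directly about the change considered here.

Compound 4 `N/C(=N\NC(=S)N1CCOCC1)c1ccc(F)cn1` is not yet measured. It differs from compound 1 by morpholin-4-yl in place of pyrrolidin-1-yl on a thiocarbonyl carbon. Compounds 2 and 3 carry yet another six-membered ring at the same place and both sit lower than compound 1, but they also differ from compound 1 in the aromatic substituent, so their numbers cannot be attributed to the ring alone.

For the measured compounds named here, with no directly comparable step available, a moderate decrease is expected, estimated as a number 14.2 percentage points lower from compound 1 to compound 4 (beyond the scatter). Compound 4 is therefore expected to give about 58%, with a range from 35% to 78%.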

Compound 4, percent growth inhibition at one concentration: 47%
Beside the measured number, compound 4's estimate is 11 percentage points above it, within the range that was stated.
By their numbers in this assay, from the lowest: compounds 3, 4 and 2 (each within the scatter of the next, the first and the last beyond it); then compound 1.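

In this assay, the ring on the thiocarbonyl carbon proves to matter on its own: with the rest of the molecule unchanged, morpholin-4-yl in place of pyrrolidin-1-yl gives a number 25.2 percentage points lower from compound 1 to compound 4 (beyond the scatter) and lies beyond the usual scatter. Among the compounds shown here, the only earlier single-place step concerned an aromatic carbon, so this is the first direct reading of this position, and between these two rings on this core, pyrrolidin-1-yl gives the higher growth inhibition at the one concentration tested. The swap alters ring size and also adds an oxygen, counted as a hydrogen-bond acceptor, and nothing available here explains the drop or assigns it to either change.

Piperidin-1-yl, a six-membered ring without the oxygen, would help separate the effect of ring size from that of the oxygen, while an open-chain dimethylamino group would ask whether a ring is needed here at all. Going by these compounds, it also remains open whether this step would keep its size on a core carrying a different group on the aromatic ring.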